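From 3-nitrophenyl to 2-chlorophenyl: what to expect

The compounds below may be only part of what the source reports. "The series", "measured", "known", "first", "only" and "open" are said of these compounds alone.

In a functional assay on MCF7 cells (Homo sapiens) for cytotoxicity, read by MTT assay, with a stated time of 24 h (a lower number here means a stronger inhibitor, a higher number a weaker inhibitor), the measured compounds read as follows:
- Compound 1 `C/C(=N\NC(=O)/C(C#N)=C/c1ccc(Br)cc1)c1c(O)c2ccc(O)cc2oc1=O` gives 9850 nM
- Compound 2 `C/C(=N\NC(=O)/C(C#N)=C/c1ccc(N(C)C)cc1)c1c(O)c2ccc(O)cc2oc1=O` gives 3420 nM
- Compound 3 `C/C(=N\NC(=O)/C(C#N)=C/c1cccc([N+](=O)[O-])c1)c1c(O)c2ccc(O)cc2oc1=O` gives 16400 nM

These compounds share one core and differ only in the phenyl group on a double-bonded chain carbon. Compound 3 cannot be told apart from compound 1: the data show a 1.7-fold higher number from compound 1 to compound 3 (0.22 log units; within the scatter) and repeat measurements of one compound can differ that much. The dimethylamino compound stands apart, with a 2.9-fold lower number from compound 1 to compound 2 (0.46 log units; beyond the scatter) and a 4.8-fold higher number from compound 2 to compound 3 (0.68 log units; beyond the scatter) on record.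

The next structure is compound 4 `C/C(=N\NC(=O)/C(C#N)=C/c1ccccc1Cl)c1c(O)c2ccc(O)cc2oc1=O` with 2-chlorophenyl in place of 3-nitrophenyl on a double-bonded chain carbon bound to a double-bonded chain carbon in full. Within the data shown here, no measured step covers this exact swap. The nearest guide is the 4-bromophenyl group, which also carries a halogen, and swapping it for 3-nitrophenyl gave a 1.7-fold higher number from compound 1 to compound 3 (0.22 log units; within the scatter) as the whole change. Among the measured compounds shown here, compound 4 has no dimethylamino group, the one change that moved the number beyond the scatter. No step beyond the scatter is therefore expected in this assay for this swap. The expected change is a 1.6-fold lower number from compound 3 to compound 4 (0.21 log units; within the scatter) as a rough estimate. Compound 4 is estimated at 10000 nM with an expected range from 4000 nM to 25000 nM for repeat measurements.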

Compound 4, half-maximal inhibitory concentration: 8880 nM
Beside the measured number, compound 4's estimate is 1.1-fold (0.05 log units) above it; measured number inside the range.
By their numbers in this assay, from the lowest: compound 2; then compounds 4, 1 and 3 (each within the scatter of the next).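

In this assay, replacing 3-nitrophenyl with 2-chlorophenyl puts a group without hydrogen-bond acceptors in place of one that has them, yet the result is only a 1.8-fold lower number from compound 3 to compound 4 (0.27 log units; within the scatter) and cannot be read as a real change, while the comparison with the bromine-bearing group, a 1.1-fold lower number from compound 1 to compound 4 (0.05 log units; within the scatter), also falls within the scatter. On a double-bonded chain carbon, then, the 2-chlorophenyl, 4-bromophenyl and 3-nitrophenyl groups cannot be separated, even though they differ in their substituent and in its place on the ring. The 4-(dimethylamino)phenyl group remains the only one that stands apart, and the new compound adds a third comparison beyond the scatter, a 2.6-fold higher number from compound 2 to compound 4 (0.41 log units; beyond the scatter), to support that. Nothing available here explains why these groups read alike or why the dimethylamino compound differs.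

On these data alone, whether the lower number of compound 2 belongs to the dimethylamino group alone stays open, since a simple amino group, a methoxy group or a carboxylic acid on the phenyl ring would be needed to test how far it extends. A plain phenyl group with no substituent would also show whether the three similar compounds sit at the baseline for this series.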